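Pyridin-2-yl in place of phenyl in the ethylcarbamoyl compounds

The compounds below may be only part of what the source reports. "The series", "measured", "known", "first", "only" and "open" are said of these compounds alone.

In an ADME assay on microsomes from liver (Rattus norvegicus) for pharmacokinetics, using NADPH, with a stated time of 30 min, tested at 1 uM (on this read-out higher numbers stand for fast clearance and lower numbers for slow clearance), compound 1 (`C[C@H](Nc1ncnc(N)c1C#N)c1nc2ccc(F)cc2c(-c2ccccn2)c1-c1ccccn1`) gives 16 mL.min-1.g-1. Compound 2 (`CCNC(=O)c1c(-c2ccccc2)c([C@H](C)Nc2ncnc(N)c2C#N)nc2ccc(F)cc12`) reads < 14 mL.min-1.g-1, which is a limit of the assay and not a number. Compound 3 (`CCNC(=O)c1c(-c2ccccn2)c([C@H](C)Nc2ncnc(N)c2C#N)nc2ccc(F)cc12`) differs from compound 2 by pyridin-2-yl in place of phenyl on an aromatic carbon, ortho to an ethylcarbamoyl group (pyridin-2-yl in place of phenyl on an aromatic carbon). Among the compounds with values here, no measured pair shows this change, so no step beyond the usual scatter is expected in this assay. The estimated step is a step that the limit leaves unreadable from compound 2 to compound 3. For compound 3 the estimate is 13 mL.min-1.g-1, with an expected range of 7 mL.min-1.g-1 to 24 mL.min-1.g-1.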

Compound 3, intrinsic clearance in microsomes: < 14 mL.min-1.g-1
Compound 3 gave a limit, no number (the forecaster's own chance of this, stated with the estimate: 50%); the middle value is on the limit's open side.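

In this assay compound 3 reads a limit of the assay and not a number, so pyridin-2-yl on this aromatic carbon, ortho to an ethylcarbamoyl group, leaves the reading at the same limit as phenyl. The step between them cannot be read, since both compounds sit at that limit: the limit of < 14 mL.min-1.g-1 in this assay, at which 2 of the 3 values shown sit.
Within the data shown here, the only readable step is an at least 1.1-fold lower number from compound 1 to compound 3 (0.05 log units; that floor lies within the scatter), for ethylcarbamoyl in place of pyridin-2-yl.

On these data alone, how far phenyl and pyridin-2-yl differ under the limit stays open. So does how an amine or a carboxylic acid on this carbon would read in this assay.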